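A few compounds are considered here, and "the series" means these few. Any claim that something is new, unique, unknown or untested is made for them only; others in the source may bear on it.

Compound 1 `O=C1C=C(Nc2ccccc2)C(=O)c2cnccc21`: 93% in a functional assay on the whole organism (aorta) with Rattus norvegicus as the target; a higher number here means a larger maximal response, a lower number a smaller maximal response
Compound 2 `O=C1C=C(Nc2ccc(F)cc2)C(=O)c2cnccc21`: 72%
Compound 3 `O=C1C=C(Nc2ccc(F)c(F)c2)C(=O)c2cnccc21`: 81%
Compound 4 `O=C1C=C(Nc2ccc(Cl)cc2)C(=O)c2cnccc21`: not yet measured

Compound 2 stands lowest of the three numbers; the nearest of them is within the scatter (a number 9 percentage points higher from compound 2 to compound 3 (within the scatter)), the furthest beyond it (a number 21 percentage points lower from compound 1 to compound 2 (beyond the scatter)).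

Compound 4 differs from compound 2 by chloro in place of fluoro on an aromatic carbon. The step that touches this place is a number 21 percentage points lower from compound 1 to compound 2 (beyond the scatter), where a fluoro entered on an aromatic carbon; the other step, a number 9 percentage points higher from compound 2 to compound 3 (within the scatter), stayed within the scatter. Among the measured compounds shown here, no measured pair swaps one halogen for another, so in this assay a step no larger than the scatter is expected, with no set direction.

Compound 4 is estimated at 70%, between 50% and 90%. For compound 4 the expected step is a number 2 percentage points lower from compound 2 to compound 4 (within the scatter).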

Compound 4, largest response reached (Emax), in percent of the reference or control that the assay uses: 96%
Compound 4: the middle estimate sits 26 percentage points below what was measured; the whole stated range lies below it.
By their numbers in this assay, from the lowest: compounds 2 and 3 (each within the scatter of the next); then compounds 1 and 4 (each within the scatter of the next).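

In this assay the halogen on this aromatic carbon, para to a large group, is not interchangeable: chloro in place of fluoro gives a number 24 percentage points higher from compound 2 to compound 4 (beyond the scatter). Chloro in place of hydrogen gives a number 3 percentage points higher from compound 1 to compound 4 (within the scatter), so the drop seen with fluoro does not extend to chloro at this position. Nothing measured on these compounds accounts for the gap between the two halogens.

Open, as far as these compounds go, is whether bromo, methyl or methoxy at this position would track chloro or fluoro. Also open, from the compounds shown here alone, is whether chloro keeps this level with a second halogen on the ring, as compound 3 carries two fluoro groups.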